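The source may report more compounds than this note shows. Statements on the series, on what has been measured and on what is new or still open speak of the compounds shown alone.

Values in a functional assay on HEK-293T cells (Homo sapiens) for cytotoxicity, read by MTT assay; on this read-out higher numbers stand for lower toxicity in this test and lower numbers for higher toxicity in this test:
- compound 1 `COc1ccc(-c2nc3cnccn3c2Nc2cc(OC)c(OC)c(OC)c2)cc1`: 54000 nM
- compound 2 `COc1cc(Nc2c(-c3cccc(O)c3)nc3cnccn23)cc(OC)c1OC`: 42000 nM
- compound 3 `COc1cc(Nc2c(-c3ccc(Cl)cc3)nc3cnccn23)cc(OC)c1OC`: 25000 nM

Compound 3, at 25000 nM, is clearly apart from only one of the other two values: the measured steps are a 2.2-fold lower number from compound 1 to compound 3 (0.33 log units; beyond the scatter) and a 1.7-fold lower number from compound 2 to compound 3 (0.23 log units; within the scatter).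

The next compound is compound 4 `COc1cc(Nc2c(-c3ccc(F)cc3)nc3cnccn23)cc(OC)c1OC`, with fluoro in place of chloro on an aromatic carbon, para to a large group: fluoro in place of chloro on an aromatic carbon. The same difference, cut one bond further out, reads 4-chlorophenyl to 4-fluorophenyl.

All three measured steps alter this same aryl group, and none exchanges one halogen for another, so the evidence is indirect. Only the chloro for methoxy exchange, the step to compound 3 given above, passes the scatter, and it is modest. The remaining step is a 1.3-fold lower number from compound 1 to compound 2 (0.11 log units; within the scatter). With changes this small across the aryl variants so far, no shift beyond the scatter is expected in this assay for this single-atom exchange. The expected step is a 1.2-fold higher number from compound 3 to compound 4 (0.08 log units; within the scatter), with any drift more likely towards the higher numbers of the other two compounds than away from them. For compound 4 the estimated value is 30000 nM, with an expected range of 15000 nM to 60000 nM.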

Compound 4, concentration lethal to 50% of the cells: 36000 nM
The estimate for compound 4 lay 1.2-fold (0.08 log units) below the measured number; measured number inside the range.
By their numbers in this assay, from the lowest: compounds 3, 4, 2 and 1 (each within the scatter of the next, the first and the last beyond it).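

In this assay, going by these compounds alone, the first exchange of one halogen for another at this position gives a 1.4-fold higher number from compound 3 to compound 4 (0.16 log units; within the scatter), so fluoro in place of chloro on an aromatic carbon, para to a large group, stays within the scatter. Compound 4 also stays within the scatter of the other two aryl variants, at a 1.2-fold lower number from compound 2 to compound 4 (0.07 log units; within the scatter) and a 1.5-fold lower number from compound 1 to compound 4 (0.18 log units; within the scatter); fluoro in place of methoxy therefore does not pass the scatter, while chloro in place of methoxy, at a 2.2-fold lower number from compound 1 to compound 3 (0.33 log units; beyond the scatter), does so only modestly, and compound 4 sits within the scatter of both ends of that pair. No supporting measurement is available to explain any of these steps.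

Going by these compounds, whether an amine or a carboxylic acid in place of the fluoro, or a longer chain at the same carbon, would give a step clearly beyond the scatter remains open. On these data alone, all four compounds share the rest of the structure, so the response of this read-out to changes elsewhere on the core of compound 1 also remains open.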